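A few compounds are considered here, and "the series" means these few. Any claim that something is new, unique, unknown or untested is made for them only; others in the source may bear on it.

Measured so far in a functional assay on NCI-H460 cells (Homo sapiens) for cytotoxicity, read by MTT assay, with a stated time of 2 days; on this read-out lower numbers stand for stronger inhibition and higher numbers for weaker inhibition:
compound 1 `c1ccc(CO/N=C2/C(c3c[nH]c4ccccc34)=Nc3ccccc32)cc1` gives 22000 nM;
compound 2 `Cc1ccc(CO/N=C2/C(c3c[nH]c4ccccc34)=Nc3ccccc32)cc1` gives 29800 nM.

Among the compounds with values here, compound 2 sits within the scatter of compound 1, so on these two numbers neither compound is set apart; the only measured step, a 1.4-fold higher number from compound 1 to compound 2 (0.13 log units; within the scatter), records how little the pair differs. Compound 3 `Fc1ccc(CO/N=C2/C(c3c[nH]c4ccccc34)=Nc3ccccc32)cc1` is not yet measured. Relative to compound 2 the change is fluoro in place of methyl on an aromatic carbon. Within the data shown here, the one step that touches this aromatic carbon is a 1.4-fold higher number from compound 1 to compound 2 (0.13 log units; within the scatter), and it was small. Among the measured compounds shown here, no measured step covers fluoro at this place, so the expectation in this assay rests only on the observation that a change at this carbon has so far moved the number by little. For compound 3 the step of a 1.2-fold lower number from compound 2 to compound 3 (0.08 log units; within the scatter) is therefore expected to stay within the scatter. Compound 3 is estimated at 25000 nM, with a range from 10000 nM to 60000 nM.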

Compound 3, half-maximal inhibitory concentration: 20700 nM
The estimate for compound 3 lay 1.2-fold (0.08 log units) above the measured number, within the range that was stated.
By their numbers in this assay, from the lowest: compounds 3, 1 and 2 (each within the scatter of the next).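

At the aromatic carbon para to a large group, this assay now covers three substituents, and fluoro does not separate from either of the other two: a 1.4-fold lower number from compound 2 to compound 3 (0.16 log units; within the scatter) against methyl, and a 1.1-fold lower number from compound 1 to compound 3 (0.03 log units; within the scatter) against hydrogen. Hydrogen, methyl and fluoro therefore cannot be told apart at this carbon, which extends the earlier methyl result to a second replacement, though only for these three compounds. Nothing available here bears on why the three compounds read alike.

As far as these compounds go, each replacement so far is a single heavy atom, so it remains open whether an amine, a carboxylic acid or a longer chain such as butoxy at this carbon would separate from these compounds. Also open, from the compounds shown here alone, is whether fluoro or methyl on another carbon of this ring would read the same.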